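Methyl on the pyridine core: a second placement tested

This account rests on a few compounds, and the source may have more. Where it says the series, first, only, none or still open, it means among the compounds named here.

Measured compounds:
compound 1 `CN1CCC[C@H]1COc1cccnc1` — 0.15 nM
compound 2 `Cc1ncccc1OC[C@@H]1CCCN1C` — 22.9 nM
compound 3 `CCN(CC)C(=O)c1ccncc1OC[C@@H]1CCCN1C` — 2830 nM

In an assay on membranes from brain for displacement of a labelled ligand from Neuronal acetylcholine receptor; alpha4/beta2 (Rattus norvegicus) (on this read-out higher numbers stand for weaker inhibition and lower numbers for stronger inhibition), compound 1 gives 0.15 nM and stands lowest of the three numbers, with compound 2 nearest and compound 3 furthest. Compound 4 `Cc1cncc(OC[C@@H]2CCCN2C)c1` is not yet measured. It differs from compound 1 by methyl in place of hydrogen on an aromatic carbon. The new methyl sits on an aromatic carbon of a six-membered aromatic ring with one nitrogen, two atoms from the ring nitrogen, meta to a group of 8 heavy atoms.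

Going by the values given here, two measured steps bear on this. The step of a 150-fold higher number from compound 1 to compound 2 (2.18 log units; beyond the scatter) shows that a methyl at another carbon of the same ring, as the structure of compound 2 shows, cost a great deal. The step of a 19000-fold higher number from compound 1 to compound 3 (4.28 log units; beyond the scatter) shows a far larger group at yet another carbon cost even more. Neither step puts a group at the carbon that changes in compound 4, so they only warn that the core is sensitive to added groups; they do not fix the size of this step. A methyl is the smallest possible addition, and a loss smaller than that seen for compound 2 is expected, so the step of a 4.0-fold higher number from compound 1 to compound 4 (0.60 log units; beyond the scatter) is estimated. Compound 4 is therefore expected to give 0.6 nM, within the range 0.15 nM to 3 nM.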

Compound 4, inhibition constant: 0.48 nM
Compound 4: middle estimate off by 1.3-fold (0.10 log units), on the high side; measured number inside the range.
By their numbers in this assay, from the lowest: compound 1; then compound 4; then compound 2; then compound 3.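

In this assay the swap of hydrogen for methyl at this carbon, two atoms from the ring nitrogen, gives a 3.2-fold higher number from compound 1 to compound 4 (0.51 log units; beyond the scatter) and so counts as a real but modest loss. The same swap at the carbon changed in compound 2 gave a 150-fold higher number from compound 1 to compound 2 (2.18 log units; beyond the scatter) as its step, so the cost of a single added methyl on this core depends strongly on which carbon carries it, and the carbon changed in compound 4 bears it far more easily. Nothing available here accounts for this difference between the two carbons.

Methyl is the only group seen at this carbon, so one small step cannot show how much room for change the position really offers: an ethyl or a longer chain might cost little more or might cost as much as the large diethylcarbamoyl group did at another carbon in compound 3. On these data alone, whether a chlorine, a methoxy group or an amine at this same carbon would keep the number close to that of compound 1 also remains open.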